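A few compounds are considered here, and "the series" means these few. Any claim that something is new, unique, unknown or untested is made for them only; others in the source may bear on it.

Measured so far, in a functional assay for inhibition, with Homo sapiens as the target; a higher number here means a weaker inhibitor, a lower number a stronger inhibitor:
Compound 1, `COc1cccc(Nc2nccc(-c3ccco3)n2)c1`, gives 400 nM.
Compound 2, `COc1cccc(Nc2nccc(-c3cccs3)n2)c1`, gives 900 nM.
Compound 3, `Cc1cc(C)cc(Nc2nccc(-c3cccs3)n2)c1`, gives 4300 nM.

Compounds 1 and 2 share one core and differ only in the five-membered ring attached to it. The change from compound 2 to compound 1 is furan-2-yl in place of thiophen-2-yl on an aromatic carbon, and it moved the read-out by a 2.3-fold lower number from compound 2 to compound 1 (0.35 log units; beyond the scatter), a modest step in the direction of stronger inhibition. Compound 3 carries a different core; the difference between the core of compound 3 and the core of compound 2 is not broken down here. Of the three, compound 3 gives the highest number in this assay.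

Compound 4, `Cc1cc(C)cc(Nc2nccc(-c3ccco3)n2)c1`, has not yet been measured. It stands to compound 3 as compound 1 stands to compound 2: the change is furan-2-yl in place of thiophen-2-yl on an aromatic carbon, the same change at the same place on the core. Going by the values given here, the expectation for compound 4 therefore rests on the single earlier instance of this change, where the step from compound 2 to compound 1 was a 2.3-fold lower number from compound 2 to compound 1 (0.35 log units; beyond the scatter). That is one pair only, and it sits on a different core, so the expected step is given a wide range. Compound 4 is expected to show a step of about a 2.3-fold lower number from compound 3 to compound 4 (0.35 log units; beyond the scatter), giving an estimated 1900 nM, most likely between 900 nM and 4000 nM.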

Compound 4, half-maximal inhibitory concentration: 700 nM
Beside the measured number, compound 4's estimate is 2.7-fold (0.43 log units) above it, outside the stated range (below it).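

In this assay, putting furan-2-yl in place of thiophen-2-yl again gives a stronger inhibitor, with a 6.1-fold lower number from compound 3 to compound 4 (0.79 log units; beyond the scatter), so the direction of this change held on both cores. The size of the step did not hold, and the two steps differ by more than repeated measurements would explain: the same change on two cores in this assay, a 2.3-fold lower number (0.35 log units; beyond the scatter) from compound 2 to compound 1 and a 6.1-fold lower number (0.79 log units; beyond the scatter) from compound 3 to compound 4, 2.7-fold (0.44 log units) apart, beyond the scatter of two such steps

This suggests that, in this series, the direction of the change may transfer more reliably than its size, but two pairs cannot establish a general rule, and these numbers do not explain why the step is larger on the core of compound 3.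

The compounds shown leave open whether the same direction would appear on a third core, such as one carrying a carboxylic acid or a longer chain. They also leave open how a phenyl ring or an amine would compare with furan-2-yl and thiophen-2-yl at this place on the six-membered aromatic ring.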